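This account rests on a few compounds, and the source may have more. Where it says the series, first, only, none or still open, it means among the compounds named here.

The compounds measured so far:

Compound 1, `Cc1c(-c2ccc(F)cc2)cc(C(=O)NC2CCCCCC2)c(=O)n1Cc1ccc(F)cc1`: in an assay on HEK293 cells for inhibition of Monoacylglycerol lipase ABHD6 (Homo sapiens), read by scintillation counting, with stated times of 30 min and 5 min (on this read-out higher numbers stand for weaker inhibition and lower numbers for stronger inhibition), compound 1 gives > 10000 nM, which is a limit of the assay.
Compound 2, `Cc1c(Br)cc(C(=O)NC2CCCCCC2)c(=O)n1Cc1ccc(F)cc1`: compound 2 gives > 10000 nM, again a limit.
Compound 3, `Cc1c(Br)cc(C(=O)NC2CCNCC2)c(=O)n1Cc1ccc(F)cc1`: compound 3 gives > 10000 nM, also a limit.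

Compound 2 therefore stands only at a limit, and the same is true of every other value shown, all three sitting at the same limit (the limit of > 10000 nM in this assay, at which 3 of the 3 values shown sit). The two measured steps, a step that the two limits leave unreadable from compound 1 to compound 2 and a step that the two limits leave unreadable from compound 2 to compound 3, run between limits and cannot be sized.

Compound 4, `Cc1c(F)cc(C(=O)NC2CCCCCC2)c(=O)n1Cc1ccc(F)cc1`, differs from compound 2 by fluoro in place of bromo on an aromatic carbon. Neither measured step bears readable information on this change, so nothing in the data points to a step in either direction beyond the scatter. Compound 4 is therefore expected to sit near the limit as well, with an estimated step that the limit leaves unreadable from compound 2 to compound 4. Compound 4 is estimated at 15000 nM, in a range from 3000 nM to 100000 nM.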

Compound 4, half-maximal inhibitory concentration: > 10000 nM
Compound 4: a limit, no number; the forecaster's own chance of this, stated with the estimate: 80%; the middle value does not contradict the limit.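

In this assay compound 4 gives > 10000 nM, which is a limit of the assay. The steps from compound 1 and from compound 2 to compound 4 therefore cannot be read. The compounds shown leave open whether any change to the shared core gives a measurable value: the limit of > 10000 nM in this assay, at which 4 of the 4 values shown sit.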